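Fluoro for cyclohexyl on the pendant phenyl of compound 2

This account rests on a few compounds, and the source may have more. Where it says the series, first, only, none or still open, it means among the compounds named here.

Measured so far:
compound 1, `Clc1ccccc1CO/N=C/c1c(-c2ccc3ccccc3c2)nc2occn12`, 1100 nM;
compound 2, `Clc1ccc(CO/N=C/c2c(-c3ccc(C4CCCCC4)cc3)nc3sccn23)cc1Cl`, > 100000 nM;
compound 3, `CC1(C)CCC(C)(C)c2cc(-c3nc4sccn4c3/C=N/OCc3ccc(Cl)c(Cl)c3)ccc21`, "not active" (no number reported).

In an assay on HepG2 cells for agonist activity at nuclear receptor subfamily 1 group I member 3 (Homo sapiens), read by a luciferase reporter, with a stated time of 23 h (a higher number here means that more compound is needed for the effect, a lower number that less compound is needed), compound 1 gives 1100 nM. Compound 2 gives only > 100000 nM in this assay, which is a limit and not a number. Compound 3 is reported as "not active" (no number reported) in this assay, with no number given. Compound 2 thus stands at the limit of > 100000 nM in this assay, at which 1 of the 3 values shown sits, and it shares the absence of a number with compound 3; only compound 1 has a measured value among the three.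

The step to compound 4, `Fc1ccc(-c2nc3sccn3c2/C=N/OCc2ccc(Cl)c(Cl)c2)cc1`, changes compound 2 in one place: fluoro in place of cyclohexyl on an aromatic carbon. For the measured compounds named here, no pair of measured compounds differing in one place is available, so the size of this step cannot be read from the data. Because compound 2 sits at the limit of > 100000 nM in this assay, at which 1 of the 3 values shown sits, any expected step can only go toward a lower number or stay beyond the measurable range. Compound 4 is expected to give 20000 nM in this assay, with a likely range from 2000 nM to 200000 nM. The expected step of an at least 5.0-fold lower number from compound 2 to compound 4 (0.69 log units; beyond the scatter) is therefore estimated as downward but uncertain, with a real chance that only a limit is again reported.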

Compound 4, half-maximal effective concentration: 670 nM
The estimate for compound 4 lay 30-fold (1.47 log units) above the measured number, and the stated range ends above it.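

On this aromatic carbon, para to a large group, the substituent separates a measurable response from none: in this assay, fluoro in place of cyclohexyl brings an at least 140-fold lower number from compound 2 to compound 4 (2.17 log units; beyond the scatter). For the compounds shown here, this is the first step that can be read between two compounds differing in one place, and it shows that the shared core of these two compounds can give a measurable response. Compound 2 enters only as a limit, so the printed size of the step is a bound and not a measured distance: the limit of > 100000 nM in this assay, at which 1 of the 4 values shown sits.

Two groups at one carbon say nothing about the range between them, and a methyl, a methoxy, an amine or a carboxylic acid there could fall anywhere. On these data alone, whether the same change carries over to the core of compound 1 also stays open.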